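A chloro for a trifluoromethyl: expecting compound 4's tolerance

The source may hold more compounds than are shown below. What is called first, only, known or untested is meant among the compounds shown, and "the series" means these compounds.

The three measured compounds share one core and differ at a single aromatic carbon. Compound 1 `COc1nc(C(C)(C)C)ccc1[C@@H](c1ccccc1)[C@@](O)(CCN(C)C)c1cccc2ccccc12` carries tert-butyl there, compound 2 `COc1nc(C2CCCCC2)ccc1[C@@H](c1ccccc1)[C@@](O)(CCN(C)C)c1cccc2ccccc12` cyclohexyl, and compound 3 `COc1nc(-c2ccc(C(F)(F)F)cc2)ccc1[C@@H](c1ccccc1)[C@@](O)(CCN(C)C)c1cccc2ccccc12` 4-(trifluoromethyl)phenyl. In a toxicity assay on Vero cells (Chlorocebus sabaeus) for cytotoxicity (a lower number here means that less compound is tolerated, a higher number that more compound is tolerated), compound 1 gives 27.6 ug/mL and compound 2 gives 32.3 ug/mL. For compound 3 the assay reports only a limit, > 50 ug/mL, so compound 3 stands at a floor rather than at a number; this is the limit of > 50 ug/mL in this assay, at which 1 of the 3 values shown sits. The measured steps are all small: a 1.2-fold higher number from compound 1 to compound 2 (0.07 log units; within the scatter), an at least 1.8-fold higher number from compound 1 to compound 3 (0.25 log units; that floor lies within the scatter) and an at least 1.5-fold higher number from compound 2 to compound 3 (0.18 log units; that floor lies within the scatter), each either within the scatter or with a floor that lies within it.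

Compound 4 `COc1nc(-c2ccc(Cl)cc2)ccc1[C@@H](c1ccccc1)[C@@](O)(CCN(C)C)c1cccc2ccccc12` differs from compound 3 in one place: chloro in place of trifluoromethyl on an aromatic carbon. Going by the values given here, no measured step touches this substituent itself; the steps that bear on it are those leading into compound 3, and together with the step from compound 1 to compound 2 they show that far larger changes at the same aromatic carbon moved this assay little. The estimated step, a number no higher from compound 3 to compound 4 (the limit leaves the size open), is therefore expected to amount to no change beyond the scatter. In this assay compound 4 is estimated at 50 ug/mL, within a range from 25 ug/mL to 100 ug/mL.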

Compound 4, half-maximal cytotoxic concentration: > 50 ug/mL
Compound 4: no number, only a limit (the forecaster's own chance of this, stated with the estimate: 55%); the middle value lies on the limit itself.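

With compound 4, a second substituted phenyl group at this aromatic carbon gives only a limit and no number in this assay, so the ceiling reached by compound 3 was not confined to the 4-(trifluoromethyl)phenyl group, and the two compounds now share it: the limit of > 50 ug/mL in this assay, at which 2 of the 4 values shown sit. The step between these two compounds cannot be read, so chloro in place of trifluoromethyl, on a carbon para to a large group, has no size that can be stated here. What can be read is an at least 1.5-fold higher number from compound 2 to compound 4 (0.18 log units; that floor lies within the scatter) and an at least 1.8-fold higher number from compound 1 to compound 4 (0.25 log units; that floor lies within the scatter); neither floor separates 4-chlorophenyl from cyclohexyl or tert-butyl beyond the scatter.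

The compounds shown leave open how far past the limit compound 3 and compound 4 really lie, and so whether chloro and trifluoromethyl differ at all in this read-out. They also leave open whether an amine or a carboxylic acid at the same carbon of the phenyl ring would bring the result back to a measurable number.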